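A few compounds are considered here, and "the series" means these few. Any claim that something is new, unique, unknown or untested is made for them only; others in the source may bear on it.

Three compounds have so far been measured in a functional assay on CAKI-1 cells (Homo sapiens) for inhibition, read by sulforhodamine B assay, with a stated time of 48 h; a higher number here means a weaker inhibitor of growth, a lower number a stronger inhibitor of growth:

compound 1, `Nc1cc(N)c2nc(-c3ccccc3)c(Oc3ccc(F)cc3)nc2c1`, with 24500 nM;
compound 2, `COc1cc(CNc2nc3cc(N)cc(N)c3nc2-c2ccccc2)cc(OC)c1OC`, with 8710 nM;
compound 3, `CCOC(=O)[C@H](CCC(=O)O)NC(=O)c1ccc(Oc2nc3cc(N)cc(N)c3nc2-c2ccccc2)cc1`, with 8710 nM.

Among these three numbers compound 1 stands highest, so it is the weakest inhibitor of growth of the set. Compound 2 and compound 3 give the same lower number. The gap between compound 1 and each of them lies beyond the usual scatter of repeated measurements. Compound 4, `Nc1cc(N)c2nc(-c3ccccc3)c(NCc3ccc(F)cc3)nc2c1`, has not yet been tested in this assay. It differs from compound 1 in a single place: (4-fluorobenzyl)amino in place of 4-fluorophenoxy on an aromatic carbon. The phenyl group and the diamino core are kept. Among the measured compounds shown here, the only guide is that both other compounds, which carry other groups on the same core, give lower numbers than compound 1, compound 2 giving 8710 nM and compound 3 giving 8710 nM. On that basis a small step toward a lower number is expected from compound 1 to compound 4, a 2.0-fold lower number from compound 1 to compound 4 (0.31 log units; beyond the scatter), of a size near the edge of the scatter. Compound 4 is therefore estimated at about 12000 nM, with a likely range from 4000 nM to 30000 nM.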

Compound 4, concentration for total growth inhibition: 37200 nM
The estimate for compound 4 lay 3.1-fold (0.49 log units) below the measured number; the measured number lies above the stated range.
By their numbers in this assay, from the lowest: compounds 2 and 3 (each within the scatter of the next); then compounds 1 and 4 (each within the scatter of the next).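

In this assay, placing (4-fluorobenzyl)amino in place of 4-fluorophenoxy on this aromatic carbon gives a 1.5-fold higher number from compound 1 to compound 4 (0.18 log units; within the scatter), so the two groups cannot be told apart at this position. Among the compounds shown here, this is the first direct step at this carbon, and it shows that an exchange of the linking atoms and a larger group can leave the number within the scatter. The entering group also has a hydrogen-bond donor that the leaving group lacks, yet no separation appears, and nothing available explains this outcome.

Still open, going by these compounds, is how a plain amino group or a short alkyl chain on this carbon would compare with these two groups. An unsubstituted benzylamino group would also be needed to show whether the fluorine matters here.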